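The compounds below may be only part of what the source reports. "The series", "measured", "known", "first", "only" and "open" are said of these compounds alone.

Working notes on the series, read in a functional assay on KG-1 cells (Homo sapiens) for cytotoxicity, read by luminescence and CellTiter-Glo, with a stated time of 3 days; a lower number here means a stronger inhibitor, a higher number a weaker inhibitor. Compound 1 (`O=C(Nc1ccc(OC(F)(F)F)cc1)c1cc(F)ccc1O`) gives 780 nM, compound 2 (`O=C(Nc1ccc(C(F)(F)F)cc1)c1cc(F)ccc1O`) gives 1700 nM and compound 3 (`O=C(Nc1ccc([N+](=O)[O-])cc1)c1cc(F)ccc1O`) gives 1100 nM. Compound 3 cannot be separated from either of the others: a 1.4-fold higher number from compound 1 to compound 3 (0.15 log units; within the scatter) and a 1.5-fold lower number from compound 2 to compound 3 (0.19 log units; within the scatter) both lie within the scatter. Only a 2.2-fold higher number from compound 1 to compound 2 (0.34 log units; beyond the scatter) goes beyond it, and modestly.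

Compound 4 (`O=C(Nc1ccccc1)c1cc(F)ccc1O`) carries hydrogen in place of nitro on an aromatic carbon, para to a large group: hydrogen in place of nitro on an aromatic carbon. Among the compounds with values here, all the measured steps exchange one group at this place for another, and none leaves hydrogen there, so they bear on this change only indirectly. The data therefore fix no direction. Since the largest exchange so far is a 2.2-fold higher number from compound 1 to compound 2 (0.34 log units; beyond the scatter), a modest step towards a higher number is expected in this assay. The expected step is a 2.3-fold higher number from compound 3 to compound 4 (0.36 log units; beyond the scatter). For compound 4 the estimated value is 2500 nM, with an expected range from 900 nM to 7000 nM.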

Compound 4, half-maximal inhibitory concentration: > 10000 nM
Compound 4 ended at the assay's limit; the forecaster's own chance of this, stated with the estimate: 10%; middle value at least 4.0-fold (0.60 log units) from the limit.
By their numbers in this assay, from the lowest: compounds 1, 3 and 2 (each within the scatter of the next, the first and the last beyond it). At a limit, above all of these: compound 4.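

In this assay compound 4, with hydrogen on this aromatic carbon, para to a large group, reads as a limit of the assay and not as a number: the limit of > 10000 nM in this assay, at which 1 of the 4 values shown sits. The steps to it are an at least 9.0-fold higher number from compound 3 to compound 4 (0.95 log units; beyond the scatter), an at least 5.8-fold higher number from compound 2 to compound 4 (0.76 log units; beyond the scatter) and an at least 12-fold higher number from compound 1 to compound 4 (1.10 log units; beyond the scatter), all beyond the scatter and all wider than the largest exchange among the substituted compounds, a 2.2-fold higher number from compound 1 to compound 2 (0.34 log units; beyond the scatter). So this position is more sensitive than those exchanges suggested: the trifluoromethoxy, trifluoromethyl and nitro compounds lie close together, while the change to hydrogen separates all three from compound 4, and no compound shown goes against this.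

From the compounds shown here alone, the true size of these steps stays open, as they rest on a limit. Also open, going by these compounds, is whether any group here would keep the number low or only some would; a methyl group, an amine or a carboxylic acid at this place would test that.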